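A Third Fluoro Added to the Shared Core

The compounds below may be only part of what the source reports. "The series", "measured", "known", "first", "only" and "open" are said of these compounds alone.

Measured compounds:
compound 1: `Fc1cccc(F)c1/C=C/c1ccccc1`, 6900 nM
compound 2: `Fc1ccccc1/C=C/c1ccccc1F`, 4300 nM

In an assay on HepG2 cells for activation of nuclear factor erythroid 2-related factor 2 (Homo sapiens), read by a luciferase reporter, with a stated time of 5 h (a higher number here means that more compound is needed for the effect, a lower number that less compound is needed), compound 2 gives the lower of the two numbers, yet compound 1 sits only within the scatter of it, so the two cannot be ordered. Compound 3 `Fc1ccccc1/C=C/c1c(F)cccc1F` differs from compound 2 by fluoro in place of hydrogen on an aromatic carbon. Among the measured compounds shown here, no measured step shows what this change does; since the two measured values lie within the scatter of each other, no shift beyond the scatter is expected in this assay, in either direction. Compound 3 is therefore estimated at 4500 nM, with a range from 1500 nM to 13000 nM. The expected step of a 1.0-fold higher number from compound 2 to compound 3 (0.02 log units; within the scatter) stays within the scatter.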

Compound 3, half-maximal effective concentration: 1400 nM
Beside the measured number, compound 3's estimate is 3.2-fold (0.51 log units) above it; the whole stated range lies above it.
By their numbers in this assay, from the lowest: compound 3; then compounds 2 and 1 (each within the scatter of the next).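

In this assay, among the compounds shown here, compound 1 and compound 2 could not be ordered, so compound 3 is the first to show that the shared core responds to fluoro in place of hydrogen on an aromatic carbon, here ortho to a group of 9 heavy atoms and meta to a fluoro group. The change gives a 3.1-fold lower number from compound 2 to compound 3 (0.49 log units; beyond the scatter) and a 4.9-fold lower number from compound 1 to compound 3 (0.69 log units; beyond the scatter) and so clears the scatter from both, though each step remains modest. From the compounds shown here alone, whether a chlorine, a methoxy group or an amine at this position would act alike stays open. Nothing available bears on why the number falls.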